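The source may report more compounds than this note shows. Statements on the series, on what has been measured and on what is new or still open speak of the compounds shown alone.

Of the compounds shown here, three have been measured in a functional assay, with a stated time of 10 min; a lower number here means a stronger inhibitor, a higher number a weaker inhibitor. Compound 1 `CSc1nc(-c2ccco2)c(C#N)c(=O)n1C` gives 79 ug/mL in this assay. Compound 2 `CN(C)c1ccc(-c2nc(NN)n(C)c(=O)c2C#N)cc1` gives 66 ug/mL. Compound 3 `CCOC(=O)c1cnn(-c2nc(-c3ccccc3O)c(C#N)c(=O)n2C)c1N` gives 58 ug/mL, the lowest of the three numbers, although its gaps to compound 2 and to compound 1 both lie within the scatter of repeated measurements, so the three sit together and none of them can be singled out as the strongest or weakest inhibitor.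

Compound 4 `CCOC(=O)c1cnn(-c2nc(-c3ccccc3Cl)c(C#N)c(=O)n2C)c1N` has not yet been measured. It differs from compound 3 in one place: chloro in place of hydroxy on an aromatic carbon, on an aromatic carbon of a six-membered aromatic ring of carbon only, ortho to a large group; read one bond further out, 2-hydroxyphenyl becomes 2-chlorophenyl. Going by the values given here, no pair of measured compounds shows the effect of this exchange, so there is no direct guide to its size. Compound 3 at 58 ug/mL sits within the scatter of compound 1 at 79 ug/mL and of compound 2 at 66 ug/mL even though those compounds differ from it in several places, which suggests a single change moves the number little. The step of a 1.0-fold higher number from compound 3 to compound 4 (0.01 log units; within the scatter) is therefore expected to remain within the scatter, in no clear direction. Compound 4 is estimated to give 60 ug/mL in this assay, with a range from 30 ug/mL to 120 ug/mL.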

Compound 4, half-maximal inhibitory concentration: 98 ug/mL
For compound 4 the middle estimate is 1.6-fold (0.21 log units) below the measured one; measured number inside the range.
By their numbers in this assay, from the lowest: compounds 3, 2, 1 and 4 (each within the scatter of the next).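

Going by these compounds alone, the exchange of chloro for hydroxy on this aromatic carbon, ortho to a large group, is the first comparison in this assay between compounds that differ in one place (a 1.7-fold higher number from compound 3 to compound 4 (0.23 log units; within the scatter)), so this position now has a direct reading where the earlier compounds offered none. Hydroxy carries a hydrogen-bond donor and acceptor and chloro carries neither, yet the two values lie within the scatter of each other, so this pair gives no sign that the hydroxy group is needed here. Nothing measured bears on a cause for this result.

The compounds shown leave open whether an amine, a methoxy group or a carboxylic acid on this aromatic carbon would stay within the scatter or move beyond it. Within the data shown here, with only this one pair, they also leave open whether the same exchange would read alike elsewhere on this ring.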